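Thiazole for chlorophenyl on the cyclopropane: expected potency

This account rests on a few compounds, and the source may have more. Where it says the series, first, only, none or still open, it means among the compounds named here.

Measured so far, in a functional assay for agonist activity at G protein-coupled receptor 88 (Homo sapiens), read by HTRF and cAMP accumulation; on this read-out higher numbers stand for an effect only at larger amounts of compound and lower numbers for an effect already at smaller amounts:
compound 1, `CC[C@H](C)[C@@H](CN(C(=O)[C@@H]1C[C@H]1c1ccccc1)c1ccc(-c2ccccc2)cc1)NC(C)=O` — compound 1 gives 5.8 nM
compound 2, `CC[C@@H](C)[C@H](N)CN(C(=O)[C@@H]1C[C@H]1c1ccccc1)c1ccc(-c2ccccc2)cc1` — compound 2 gives 1.4 nM
compound 3, `CC[C@H](C)[C@H](N)CN(C(=O)[C@@H]1C[C@H]1c1ccc(Cl)cc1)c1ccc(-c2ccccc2)cc1` — compound 3 gives 4300 nM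

In this assay compound 3 stands at the highest number of the three measured; compound 1 lies far below it and compound 2 further still. For the measured compounds named here, the only measured step with a single change, a 4.1-fold lower number from compound 1 to compound 2 (0.62 log units; beyond the scatter), concerns the chain carbon bound to the amide-type nitrogen and leaves the ring on the cyclopropane untouched. Going by the values given here, compound 2 and compound 3 differ in more than one place, so their two values show only that those changes together go with a much higher number.

Compound 4, `CC[C@H](C)[C@H](N)CN(C(=O)[C@@H]1C[C@H]1c1nccs1)c1ccc(-c2ccccc2)cc1`, differs from compound 3 by 1,3-thiazol-2-yl in place of 4-chlorophenyl on a saturated ring carbon. Among the compounds with values here, no measured step bears on a change at this ring, so nothing here sets a direction. The step of a 1.4-fold lower number from compound 3 to compound 4 (0.16 log units; within the scatter) is therefore expected to lie near none beyond the scatter, with wide bounds on either side. Compound 4 is estimated at 3000 nM, expected within 400 nM to 20000 nM.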

Compound 4, half-maximal effective concentration: 210 nM
For compound 4 the middle estimate is 14-fold (1.15 log units) above the measured one, and the stated range ends above it.
By their numbers in this assay, from the lowest: compound 2; then compound 1; then compound 4; then compound 3.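

In this assay, for the compounds shown here, the first measured change at this position gives a 20-fold lower number from compound 3 to compound 4 (1.31 log units; beyond the scatter), so the group on the saturated ring carbon of the cyclopropane has a large bearing on the read-out, which the earlier single step could not show. With the rest of the structure held constant, a five-membered aromatic ring with 2 hetero atoms, 1,3-thiazol-2-yl, gives a clearly lower number than the six-membered 4-chlorophenyl ring. Nothing available explains the size of this step.

From the compounds shown here alone, it remains open whether the step comes from losing the chlorine or from gaining the thiazole, which a plain phenyl, a pyridin-2-yl or a 1,3-oxazol-2-yl on the core of compound 3 would help separate. Also open, going by these compounds, is whether the same ring change carries the same size with the stereochemistry of the 1-amino-2-methylbutyl group in compound 2.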